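A few compounds are considered here, and "the series" means these few. Any claim that something is new, unique, unknown or untested is made for them only; others in the source may bear on it.

Of the compounds shown here, three have so far been measured in an assay on isolated protein for inhibition of Leucine-rich repeat serine/threonine-protein kinase 2 variant G2019S (Homo sapiens), read by TR-FRET and LanthaScreen, with stated times of 50 min and 30 min, in the presence of a further agent that is not named here; on this read-out higher numbers stand for weaker inhibition and lower numbers for stronger inhibition. Compound 1 `C[C@@H]1CCCN1c1c(C#N)c2c(N)nc(Nc3cn[nH]c3)nc2n1C` gives 6 nM, the lowest of the three numbers and therefore the strongest inhibition among them. Compound 2 `Cc1c(Nc2nc(N)c3c(C#N)c(N4CCC[C@H]4C)n(C)c3n2)cnn1CC(C)(C)O` gives 35 nM, and compound 3 `C[C@@H]1CCCN1c1[nH]c2ncnc(N)c2c1C#N` gives 201 nM; both of these gaps from compound 1 lie beyond the usual scatter of repeated measurements. Compound 4 `C[C@@H]1CCCN1c1c(C#N)c2c(N)nc(Nc3cn(C)nc3C(F)(F)F)nc2n1C` is not yet measured. It differs from compound 1 in one place: 1-methyl-3-(trifluoromethyl)-1H-pyrazol-4-yl in place of 1H-pyrazol-4-yl on a nitrogen on an aromatic ring. Among the measured compounds shown here, no measured pair shows exactly this change. Compound 2, whose 1H-pyrazol-4-yl also carries substituents, gives 35 nM, a higher number than compound 1, so a modest loss of inhibition is expected. The expected step is a 3.3-fold higher number from compound 1 to compound 4 (0.52 log units; beyond the scatter). For compound 4 in this assay the estimate is 20 nM, with a range from 5 nM to 80 nM.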

Compound 4, half-maximal inhibitory concentration: 358 nM
For compound 4 the middle estimate is 18-fold (1.25 log units) below the measured one; measured number above the stated range.
By their numbers in this assay, from the lowest: compound 1; then compound 2; then compounds 3 and 4 (each within the scatter of the next).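

Swapping 1H-pyrazol-4-yl for 1-methyl-3-(trifluoromethyl)-1H-pyrazol-4-yl in this assay gives a 60-fold higher number from compound 1 to compound 4 (1.78 log units; beyond the scatter) and is a large step, the first one read directly at this position. It shows that this position does not tolerate every substituted pyrazole, and that this particular change costs much inhibition. Nothing available explains the loss.

From the compounds shown here alone, the change adds a methyl and a trifluoromethyl together, so their separate shares remain unknown. Also open, going by these compounds, is how a pyrazole carrying a single methyl, a chlorine atom or an amine would behave here.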